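This account rests on a few compounds, and the source may have more. Where it says the series, first, only, none or still open, it means among the compounds named here.

Measured in a functional assay on HL-60 cells (Homo sapiens) for inhibition, read by CCK-8 assay, with a stated time of 48 h; on this read-out lower numbers stand for stronger inhibition and higher numbers for weaker inhibition:
- compound 1 `Nc1ccc(Oc2ccccc2-c2ccc(S(=O)(=O)NCCNC(=O)Nc3ccc(Cl)cc3)s2)cc1` gives > 50000 nM (a limit, not a number)
- compound 2 `Cc1ccc(-c2ccsc2S(=O)(=O)NCCNC(=O)Nc2cc(C(F)(F)F)cc(C(F)(F)F)c2)c(Oc2ccc(O)c(O)c2)c1` gives 3700 nM
- compound 3 `O=C(NCCNS(=O)(=O)c1sccc1-c1ccccc1Oc1ccc(O)c(O)c1)Nc1cc(C(F)(F)F)cc(C(F)(F)F)c1` gives 5700 nM

For the measured compounds named here, compound 2 and compound 3 hold the only two actual numbers in the set, and they lie within the scatter of each other (a 1.5-fold higher number from compound 2 to compound 3 (0.19 log units; within the scatter)). Compound 4 `COc1ccc(Oc2cc(C)ccc2-c2ccsc2S(=O)(=O)NCCNC(=O)Nc2cc(C(F)(F)F)cc(C(F)(F)F)c2)cc1OC` is read here against compound 2. The change is 3,4-dimethoxyphenyl in place of 3,4-dihydroxyphenyl on an oxygen on an aromatic ring.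

Going by the values given here, the one measured step, a hydrogen in place of methyl on an aromatic carbon, does not touch this group and gives no size for the change. Among the compounds with values here, compound 1 is the only measured compound without the 3,4-dihydroxyphenyl group, and it stands at a limit (> 50000 nM). It differs from compound 2 in more than one place, so it is only a weak hint and not a step.

In this assay a moderate move towards a higher number is therefore expected, with a result within the scatter still possible. The estimated change is a 2.4-fold higher number from compound 2 to compound 4 (0.39 log units; beyond the scatter) and carries wide uncertainty. For compound 4 the expected value is 9000 nM, with an estimated range from 2500 nM to 35000 nM.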

Compound 4, half-maximal inhibitory concentration: 5300 nM
Estimate against measurement, compound 4: 1.7-fold (0.23 log units) above; measured number inside the range.
By their numbers in this assay, from the lowest: compounds 2, 4 and 3 (each within the scatter of the next). At a limit, above all of these: compound 1.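

In this assay, for the compounds shown here, replacing 3,4-dihydroxyphenyl with 3,4-dimethoxyphenyl on the oxygen gives a 1.4-fold higher number from compound 2 to compound 4 (0.16 log units; within the scatter), the first size for a change at this position. In this pair, the hydrogen-bond donors of the 3,4-dihydroxyphenyl group are absent from the entering group, yet the two values remain within the scatter of each other, so free hydroxyl groups are not needed here for a value in this range. Compound 4 lacks the 3,4-dihydroxyphenyl group and still gives an actual number, so the absence of that group does not by itself go with a limit, and the weak hint from compound 1 loses most of its weight.

On these data alone, what sets compound 1 apart stays unresolved, as it differs from the other compounds in more than one place and gives a limit, not a number: the limit of > 50000 nM in this assay, at which 1 of the 4 values shown sits. Also open is whether this position holds its values with a group other than a substituted phenyl on the oxygen, such as a carboxylic acid or a longer alkyl chain, and whether the 3,4-dimethoxyphenyl change reads the same on the core of compound 3.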